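Benzyloxy in Place of Allyloxy: Cytotoxicity Still Unknown

The source may hold more compounds than are shown below. What is called first, only, known or untested is meant among the compounds shown, and "the series" means these compounds.

compound 1, `OC[C@H](NC[C@H]1NC[C@H](O)[C@@H]1O)c1ccc(-c2ccccc2)cc1`: > 200000 nM
compound 2, `OC[C@H](NC[C@H]1NC[C@H](O)[C@@H]1O)c1ccc(-c2ccsc2)cc1`: "not active" (no number reported)
compound 3, `C=CCOc1ccc([C@H](CO)NC[C@H]2NC[C@H](O)[C@@H]2O)cc1`: > 200000 nM

In a functional assay on PC-3 cells (Homo sapiens) for cytotoxicity, read by colorimetric assay, with a stated time of 72 h (a higher number here means a weaker inhibitor, a lower number a stronger inhibitor), compound 3 stands only at a limit, > 200000 nM. Compound 1 likewise sits at a limit. For compound 2 no number was reported at all. Within the data shown here, two of the three values rest at the limit of > 200000 nM in this assay, at which 2 of the 3 values shown sit, so the single measured step, a step that the two limits leave unreadable from compound 1 to compound 3, cannot be read. Compound 4, `OC[C@H](NC[C@H]1NC[C@H](O)[C@@H]1O)c1ccc(OCc2ccccc2)cc1`, differs from compound 3 by phenyl in place of vinyl on a saturated chain carbon bound to an oxygen on an aromatic ring. Among the measured compounds shown here, no measured step bears on this exchange, and the one step available is unreadable, so no direction can be drawn from the data. Compound 4 is therefore expected to stay at the limit too, estimated at 200000 nM with a range from 100000 nM to 400000 nM. The expected step is a number no higher from compound 3 to compound 4 (the limit leaves the size open), nothing beyond the scatter.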

Compound 4, half-maximal inhibitory concentration: "not active" (no number reported)
The entry for compound 4 holds no number; there is nothing to compare the estimate with.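

Among these compounds, compound 4 has no number and compound 3 stands only at a limit, so no step between them can be read. The compounds shown leave open whether any of these exchanges shifts the read-out in this assay at all: the limit of > 200000 nM in this assay, at which 2 of the 4 values shown sit.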